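The source may hold more compounds than are shown below. What is called first, only, known or untested is meant among the compounds shown, and "the series" means these compounds.

Compound 1 `CCNC(=O)c1noc(-c2cc(C(C)C)c(O)cc2O)c1-c1cc(CNC(C)C)no1` and compound 2 `CCNC(=O)c1noc(-c2cc(C(C)C)c(O)cc2O)c1-c1cc(C(=O)OCC)no1` share a common core and differ in a single group. Among the compounds with values here, in a functional assay on A2780 cells (Homo sapiens) for inhibition (on this read-out lower numbers stand for stronger inhibition and higher numbers for weaker inhibition), compound 1 gives 38 nM, the lowest of the two numbers known so far, while compound 2 gives 9000 nM. That one exchange, ethoxycarbonyl in place of (isopropylamino)methyl on an aromatic carbon, brought a 240-fold higher number from compound 1 to compound 2 (2.37 log units; beyond the scatter). Compound 3 `CCNC(=O)c1noc(-c2cc(C(C)C)c(O)cc2O)c1-c1cnn(C)c1` has not yet been measured; it differs from compound 1 as follows: 1-methyl-1H-pyrazol-4-yl in place of 3-((isopropylamino)methyl)-1,2-oxazol-5-yl on an aromatic carbon. Within the data shown here, the only measured step that bears on this change is the large one from compound 1 to compound 2, which also removed the (isopropylamino)methyl group. Compound 3 loses that group together with the ring that carried it, so a step upward in this assay beyond the scatter is expected, although the ethoxycarbonyl of compound 2 is absent here and the size remains uncertain. Compound 3 is therefore expected to give 1500 nM, within a range from 300 nM to 8000 nM, which corresponds to an expected 39-fold higher number from compound 1 to compound 3 (1.60 log units; beyond the scatter).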

Compound 3, half-maximal inhibitory concentration: 20 nM
Estimate against measurement, compound 3: 75-fold (1.88 log units) above, outside the stated range (below it).
By their numbers in this assay, from the lowest: compounds 3 and 1 (each within the scatter of the next); then compound 2.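

In this assay the exchange of 3-((isopropylamino)methyl)-1,2-oxazol-5-yl for 1-methyl-1H-pyrazol-4-yl gives a 1.9-fold lower number from compound 1 to compound 3 (0.28 log units; within the scatter), so at this position the (isopropylamino)methyl group and its hydrogen-bond donor are not needed for a number in this low range. Set against the ester-bearing ring, the same 1-methyl-1H-pyrazol-4-yl gives a 450-fold lower number from compound 2 to compound 3 (2.65 log units; beyond the scatter), which means the high number of compound 2 cannot be read simply as the loss of the amine and instead goes with the 3-(ethoxycarbonyl)-1,2-oxazol-5-yl group as a whole. No measurement on these compounds explains why compound 1 and compound 3 lie within the scatter of each other or why compound 2 stands so far from both.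

The ring and its side chain changed together in each of these steps, so the compounds shown do not separate their contributions, and a bare 1,2-oxazol-5-yl or a 1H-pyrazol-4-yl without its methyl would be needed to do so. They also leave open whether a carboxylic acid or a primary aminomethyl group on the 1,2-oxazole would sit with compound 2 or with compound 1.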